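Nitro to Dimethylamino, Tested on a Second Core

This account rests on a few compounds, and the source may have more. Where it says the series, first, only, none or still open, it means among the compounds named here.

Compound 1 `CNC(=O)c1cccc(S(=O)(=O)Oc2ccc(-c3cncn3C3CCN(C(=O)c4ccc([N+](=O)[O-])cc4)CC3)cc2)c1` and compound 2 `CNC(=O)c1cccc(S(=O)(=O)Oc2ccc(-c3cncn3C3CCN(C(=O)c4ccc(N(C)C)cc4)CC3)cc2)c1` share one core and differ in a single place: dimethylamino in place of nitro on an aromatic carbon. In an assay on HEK293 cells for antagonist activity at P2X purinoceptor 7 (Homo sapiens), read by fluorescence, with a stated time of 2 h (a lower number here means a stronger inhibitor, a higher number a weaker inhibitor), compound 1 gives 62 nM, and compound 2 gives 25 nM, so the change produced a 2.5-fold lower number from compound 1 to compound 2 (0.39 log units; beyond the scatter).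

Compound 3 `O=C(c1ccc([N+](=O)[O-])cc1)N1CCN(c2cc(=O)[nH]c(=O)n2Cc2ccc(OS(=O)(=O)c3cccc4cnccc34)cc2)CC1` is built on a different core; how that core differs from the core of compound 1 is not broken down here. In this assay compound 3 gives 27 nM. Compound 4 `CN(C)c1ccc(C(=O)N2CCN(c3cc(=O)[nH]c(=O)n3Cc3ccc(OS(=O)(=O)c4cccc5cnccc45)cc3)CC2)cc1` carries the same change as before: dimethylamino in place of nitro on an aromatic carbon.

The step to compound 4 is expected to read a 2.5-fold lower number from compound 3 to compound 4 (0.39 log units; beyond the scatter), because the same change at the same place gave a 2.5-fold lower number from compound 1 to compound 2 (0.39 log units; beyond the scatter). Compound 4 is therefore expected to give about 11 nM in this assay, with an estimated range from 5 nM to 25 nM, resting on a single earlier example.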

Compound 4, half-maximal inhibitory concentration: 1.53 nM
The estimate for compound 4 lay 7.2-fold (0.86 log units) above the measured number, outside the stated range (below it).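

The change from nitro to dimethylamino gave a lower number on both cores, and on the second core the result was an 18-fold lower number from compound 3 to compound 4 (1.25 log units; beyond the scatter) in this assay. The direction carried over from one core to the other, but the size did not: the same change on two cores in this assay, a 2.5-fold lower number (0.39 log units; beyond the scatter) from compound 1 to compound 2 and an 18-fold lower number (1.25 log units; beyond the scatter) from compound 3 to compound 4, 7.1-fold (0.85 log units) apart, beyond the scatter of two such steps. These two pairs do not show why the size differs, and two cores are too few to predict the size of the step on a third core.

The compounds shown leave open whether other groups in the same place, such as a plain amino group or a carboxylic acid, would also depend on the core. They also leave open whether any such group would give a lower number than dimethylamino.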